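The source may report more compounds than this note shows. Statements on the series, on what has been measured and on what is new or still open speak of the compounds shown alone.

Compound 1 `CN(C)c1ccc(C(=O)N2CCC(NS(=O)(=O)c3cc(S(=O)(=O)c4ccccc4)ccc3C(F)(F)F)CC2)cc1` gives 190 nM in an assay on U2OS cells for inhibition of secreted frizzled-related protein 1 (Homo sapiens), read by a luciferase reporter, with a stated time of 18 h (a lower number here means that less compound is needed, a higher number that more compound is needed for the effect), the highest of the three numbers recorded in this set. Compound 2 `CN(C)c1ccc(C(=O)N2CCC(NS(=O)(=O)c3cc(S(=O)(=O)c4ccccc4)ccc3C(F)(F)F)CC2)cn1` gives 70 nM and compound 3 `O=C(O)c1ccc(S(=O)(=O)N2CCC(NS(=O)(=O)c3cc(S(=O)(=O)c4ccccc4)ccc3C(F)(F)F)CC2)cc1` gives 110 nM. Compound 4 `N#Cc1cccc(S(=O)(=O)N2CCC(NS(=O)(=O)c3cc(S(=O)(=O)c4ccccc4)ccc3C(F)(F)F)CC2)c1` is not yet measured; it differs from compound 1 as follows: (3-cyanophenyl)sulfonyl in place of (4-(dimethylamino)phenyl)carbonyl on an amine nitrogen in a ring. Among the compounds with values here, the closest precedent is a 1.7-fold lower number from compound 1 to compound 3 (0.24 log units; within the scatter), where a sulfonyl-linked aryl likewise replaced the carbonyl-linked one; a 2.7-fold lower number from compound 1 to compound 2 (0.43 log units; beyond the scatter) shows that altering the aryl ring alone gave a modest gain. Neither precedent points to a large move, so for compound 4 a step of a 1.6-fold lower number from compound 1 to compound 4 (0.20 log units; within the scatter) is expected, not clearly beyond the scatter. The estimated value for compound 4 is 120 nM, with a range of 50 nM to 300 nM.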

Compound 4, half-maximal effective concentration: 170 nM
Compound 4: the middle estimate sits 1.4-fold (0.15 log units) below what was measured; measured number inside the range.
By their numbers in this assay, from the lowest: compounds 2, 3, 4 and 1 (each within the scatter of the next, the first and the last beyond it).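

At the amine nitrogen in the ring, (3-cyanophenyl)sulfonyl does not clearly separate from (4-(dimethylamino)phenyl)carbonyl in this assay, with a 1.1-fold lower number from compound 1 to compound 4 (0.05 log units; within the scatter). On the sulfonyl sulfur, a carboxylic acid is not needed to stay within the scatter, with a 1.5-fold higher number from compound 3 to compound 4 (0.19 log units; within the scatter). Only (6-(dimethylamino)pyridin-3-yl)carbonyl stands apart from the new group, with a 2.4-fold higher number from compound 2 to compound 4 (0.39 log units; beyond the scatter).

No measurement here accounts for these steps. Still open, on these data alone, is whether a primary amine or a methoxy group on the aryl ring of the sulfonyl would give a number like that of compound 2 or remain with compound 4.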